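This account rests on a few compounds, and the source may have more. Where it says the series, first, only, none or still open, it means among the compounds named here.

Compound 1, `COc1ccc(-c2cc(/C=C/C(=O)c3ccc(OC)c(OC)c3)[nH]n2)cc1` — in a functional assay on NCI/ADR-RES cells (Homo sapiens) for inhibition, read by sulforhodamine B assay, with a stated time of 48 h (on this read-out lower numbers stand for stronger inhibition of growth and higher numbers for weaker inhibition of growth), compound 1 gives 3440 nM.
Compound 2, `COc1cc(-c2cc(/C=C/C(=O)c3ccc(Cl)c(Cl)c3)[nH]n2)cc(OC)c1OC` — in this assay compound 2 gives 10600 nM.
Compound 3, `COc1ccc(-c2cc(/C=C/C(=O)c3cc(OC)c(OC)c(OC)c3)[nH]n2)cc1OC` — in this assay compound 3 gives 2690 nM.

Of these three, compound 2 stands at the highest number, and its gap to each of the other two lies beyond the scatter of repeated measurements; it is thus the weakest of the three on this read-out. Compound 2 is the only one of the three that carries a 3,4-dichlorophenyl on the carbonyl carbon, while compounds 1 and 3 carry methoxy-bearing aryl groups there.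

Compound 4, `COc1ccc(C(=O)/C=C/c2cc(-c3cc(OC)c(OC)c(OC)c3)n[nH]2)cc1OC`, has not yet been measured. It differs from compound 2 in one place: 3,4-dimethoxyphenyl in place of 3,4-dichlorophenyl on a carbonyl carbon. The group on the carbonyl carbon of compound 4 is the same 3,4-dimethoxyphenyl found on the carbonyl carbon of compound 1.

Among the compounds with values here, no measured pair differs in one place, so no measured step guides the expectation directly. Still, because compound 1 gives 3440 nM and compound 3 gives 2690 nM, both methoxy-bearing analogues sitting well below compound 2, a step toward a lower number beyond the scatter is expected in this assay, of the size a 3.0-fold lower number from compound 2 to compound 4 (0.48 log units; beyond the scatter). Compound 4 is therefore estimated at 3500 nM, with a range from 1500 nM to 8000 nM.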

Compound 4, concentration for 50% growth inhibition: 3130 nM
Beside the measured number, compound 4's estimate is 1.1-fold (0.05 log units) above it, and the stated range covers the measured number.
By their numbers in this assay, from the lowest: compounds 3, 4 and 1 (each within the scatter of the next); then compound 2.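

The change to 3,4-dimethoxyphenyl in place of 3,4-dichlorophenyl on a carbonyl carbon gives a 3.4-fold lower number from compound 2 to compound 4 (0.53 log units; beyond the scatter) in this assay. Within the data shown here, until now no pair differed in one place, so the group on the carbonyl carbon had not been read alone; this pair shows that the change at this position, with the rest of the molecule held constant, moves the number beyond the scatter. No measurement shown offers a reason for this step.

As far as these compounds go, with only these two groups compared at this position, it remains open whether the step follows from losing the chlorines or from gaining the methoxy groups. An unsubstituted phenyl, or a phenyl carrying a single chlorine, a single methoxy group or an amine, on the carbonyl carbon would help to separate the two readings.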